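Swapping Methyl for Fluoro on Compound 2

The source may hold more compounds than are shown below. What is called first, only, known or untested is meant among the compounds shown, and "the series" means these compounds.

For the measured compounds named here, in a functional assay on T-24 cells (Homo sapiens) for cytotoxicity, read by CCK-8 assay, with a stated time of 24 h (on this read-out lower numbers stand for stronger inhibition and higher numbers for weaker inhibition), the series so far holds only two entries, and neither gives a number. Compound 1 `C/C(=C\c1cc(C2=CCCC2)co1)C(N)=O` is one of them. In this assay compound 1 reaches only the limit of > 50000 nM. Compound 2 `C/C(=C\c1ccc(-c2ccc(C)cc2)o1)C(N)=O` is the other. In this assay compound 2 likewise stops at the limit of > 50000 nM. Going by the values given here, compound 2 therefore stands at the limit of > 50000 nM in this assay, at which 2 of the 2 values shown sit, so there is no numerical value by which to rank it, and no step between measured compounds can be drawn from such data.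

Compound 3 `C/C(=C\c1ccc(-c2ccc(F)cc2)o1)C(N)=O` is not yet measured. It differs from compound 2 by fluoro in place of methyl on an aromatic carbon. Among the compounds with values here, no measured step bears on this change, so the size of the step from compound 2 to compound 3 can only be guessed; given that compound 2 sits at the limit of > 50000 nM, the expectation is a step that the limit leaves unreadable from compound 2 to compound 3, that is, none beyond the scatter, with compound 3 most likely also reported as a limit. On that basis compound 3 is estimated at 80000 nM, within a range from 30000 nM to 200000 nM.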

Compound 3, half-maximal inhibitory concentration: 3320 nM
Beside the measured number, compound 3's estimate is 24-fold (1.38 log units) above it, outside the stated range (below it).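

Compound 3 gives the series its first number rather than a limit in this assay, showing that the group on this aromatic carbon, para to a large group, can decide whether the read-out leaves the limit. Fluoro in place of methyl produces an at least 15-fold lower number from compound 2 to compound 3 (1.17 log units; beyond the scatter), although the exchange swaps one heavy atom for one heavy atom and involves no ring, hydrogen-bond donor, hydrogen-bond acceptor or net charge. That step gives only a minimum size, since the value for compound 2 is a limit and not a number: the limit of > 50000 nM in this assay, at which 2 of the 3 values shown sit.

The compounds shown cannot separate an effect of fluoro itself from one of losing methyl, and they offer no comparison with hydrogen, chloro, methoxy or trifluoromethyl at this position. They also leave open whether a nitrile or a carboxylic acid in place of the amide would preserve the result seen with compound 3.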